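Taking one methyl off the amide of compound 2

The source may hold more compounds than are shown below. What is called first, only, known or untested is meant among the compounds shown, and "the series" means these compounds.

Compound 1 `CC[C@H](C)[C@@H]1C(=O)N[C@H](C2Cc3ccccc3C2)C(=O)N1[C@@H](C(=O)N1CCOCC1)c1cnc(C)cc1C`: 1110 ng.h/mL
Compound 2 `CC[C@H](C)[C@@H]1C(=O)N[C@H](C2Cc3ccccc3C2)C(=O)N1[C@@H](C(=O)N(C)C)c1cnc(C)cc1C`: 2690 ng.h/mL

In an ADME assay on the whole organism (plasma) for pharmacokinetics, with Rattus norvegicus as the target, at a dose of 5 mg/kg by the oral route (on this read-out higher numbers stand for higher exposure at the dose given and lower numbers for lower exposure), compound 2 stands highest of the two measured compounds at 2690 ng.h/mL. The next compound, compound 3 `CC[C@H](C)[C@@H]1C(=O)N[C@H](C2Cc3ccccc3C2)C(=O)N1[C@@H](C(=O)NC)c1cnc(C)cc1C`, differs from it in one place: hydrogen in place of methyl on an amide-type nitrogen. In words, this is hydrogen in place of methyl on an amide-type nitrogen.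

Among the compounds with values here, only one measured step bears on this change: a 2.4-fold higher number from compound 1 to compound 2 (0.38 log units; beyond the scatter). There, dimethylamino took the place of morpholin-4-yl on a carbonyl carbon. That step is modest but beyond the usual scatter. It is a different structural change, however, so it offers only a rough guide to size and no firm direction. Within the data shown here, no measured pair yet shows what losing this methyl does. A small step is therefore expected, slightly downward if anything, and it may well stay within the scatter. The expected change is a 1.3-fold lower number from compound 2 to compound 3 (0.13 log units; within the scatter). Compound 3 is estimated at 2000 ng.h/mL, with an expected range of 700 ng.h/mL to 5500 ng.h/mL.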

Compound 3, area under the concentration-time curve: 407 ng.h/mL
Estimate against measurement, compound 3: 4.9-fold (0.69 log units) above; measured number below the stated range.
By their numbers in this assay, from the lowest: compound 3; then compound 1; then compound 2.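

In this assay, a single methyl on the amide-type nitrogen turns out to count for a lot: putting hydrogen in its place gives a 6.6-fold lower number from compound 2 to compound 3 (0.82 log units; beyond the scatter). Compared with the morpholin-4-yl amide, the methylamino group also falls short, with a 2.7-fold lower number from compound 1 to compound 3 (0.44 log units; beyond the scatter), so the change from morpholin-4-yl to a smaller group on this carbonyl carbon can move the number either way, depending on which small group is chosen. Among these three compounds, compound 1 and compound 2 have no hydrogen on that nitrogen and compound 3 does, and compound 3 has the lowest number, with both of its steps beyond the scatter.

Nothing measured here explains why the number drops when the methyl goes, so the reason stays unknown. From the compounds shown here alone, it also remains open whether this trend continues with the unsubstituted amide, where two hydrogens sit on the nitrogen, and whether a larger group there, such as diethylamino or a pyrrolidine ring, would stay close to compound 2 or fall away from it.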